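The source may hold more compounds than are shown below. What is called first, only, known or untested is meant among the compounds shown, and "the series" means these compounds.

Compound 1 `Cc1ccc(C(=O)NC(N)=O)cc1NC(=O)C(C)Br` and compound 3 `Cc1ccc(C(=O)NC(N)=O)cc1NC(=O)CBr` share one core. In a functional assay on CCRF-CEM cells (Homo sapiens) for antiproliferative activity, read by trypan blue exclusion, with a stated time of 72 h (a higher number here means a weaker inhibitor, a lower number a stronger inhibitor), compound 1 gives 3360 nM. In this assay compound 3 gives 4280 nM. The change between them, (hydrogen in place of methyl on a saturated chain carbon bound to a bromine atom and a carbonyl carbon), made a step of a 1.3-fold higher number from compound 1 to compound 3 (0.11 log units; within the scatter). Compound 2 `Cc1ccc(NC(=O)C(C)Br)cc1C(=O)NC(N)=O` is made of the same atoms as compound 1 joined differently; how the two cores differ is not broken down here. In this assay compound 2 gives only a limit, > 20000 nM, as marked by the limit of > 20000 nM in this assay, at which 1 of the 3 values shown sits. Compound 4 `Cc1ccc(NC(=O)CBr)cc1C(=O)NC(N)=O` carries the same change on the core of compound 2, (hydrogen in place of methyl on a saturated chain carbon bound to a bromine atom and a carbonyl carbon). Because a 1.3-fold higher number from compound 1 to compound 3 (0.11 log units; within the scatter) stayed within the scatter, a step of similar size, a step that the limit leaves unreadable from compound 2 to compound 4, is expected here. Compound 4 is therefore estimated at 25000 nM in this assay, between 10000 nM and 60000 nM.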

Compound 4, half-maximal inhibitory concentration: 4760 nM
For compound 4 the middle estimate is 5.3-fold (0.72 log units) above the measured one, and the stated range ends above it.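

Replacing methyl with hydrogen on a saturated chain carbon bound to a bromine atom and a carbonyl carbon gave an at least 4.2-fold lower number from compound 2 to compound 4 (0.62 log units; beyond the scatter), so the change did not carry over from one core to the other with the same size: the same change on two cores in this assay, a 1.3-fold higher number (0.11 log units; within the scatter) from compound 1 to compound 3 and an at least 4.2-fold lower number (0.62 log units; beyond the scatter) from compound 2 to compound 4, at least 5.3-fold (0.72 log units) apart, beyond the scatter of two such steps

In this assay compound 2 gives > 20000 nM, which is a limit and not a number, so the full size of its step remains unknown: the limit of > 20000 nM in this assay, at which 1 of the 4 values shown sits.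

This pair shows that the outcome of the change differed between two cores, but not why it differed or how it would behave on any other core.

Still open, from the compounds shown here alone, is whether chlorine in place of the bromine atom, or a longer chain in place of 1-bromoethyl, would show the same difference between the two cores.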